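A few compounds are considered here, and "the series" means these few. Any claim that something is new, unique, unknown or untested is made for them only; others in the source may bear on it.

Compound 1, `N#CC1=C(N)Oc2c(c3nc4ccccc4nc3c3ccccc23)C12C(=O)N(Cc1cnnn1-c1ccc(N)cc1)c1ccccc12`: 45200 nM
Compound 2, `N#CC1=C(N)Oc2c(N)cc3nc4ccccc4nc3c2C12C(=O)N(Cc1cnnn1-c1cccc(C(F)(F)F)c1)c1ccccc12`: 18900 nM

Both compounds were tested in a functional assay on HCT-116 cells (Homo sapiens) for antiproliferative activity, read by MTT assay, with a stated time of 48 h; a higher number here means a weaker inhibitor, a lower number a stronger inhibitor. Compound 2 gives the lower of the two numbers, 18900 nM, and its gap to compound 1 lies beyond the usual scatter, so compound 2 is the stronger inhibitor of this pair. The two differ in more than one place, so their values speak only for themselves and no single change can be credited.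

Compound 3, `Cc1ccc(Cl)cc1-n1nncc1CN1C(=O)C2(C(C#N)=C(N)Oc3c(N)cc4nc5ccccc5nc4c32)c2ccccc21`, has not yet been measured. It keeps the shared core of compound 2 and differs in one place: 5-chloro-2-methylphenyl in place of 3-(trifluoromethyl)phenyl on an aromatic nitrogen. Both groups are a six-membered aromatic ring of carbon only, with no hydrogen-bond donors or acceptors and no net charge. Among the measured compounds shown here, no measured pair in this set differs only at that aromatic nitrogen, so nothing here shows how much that position matters. In this assay the expected step is a 1.1-fold higher number from compound 2 to compound 3 (0.02 log units; within the scatter), small and within the scatter. Compound 3 is therefore estimated at 20000 nM, with a range from 8000 nM to 50000 nM.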

Compound 3, half-maximal inhibitory concentration: 37200 nM
For compound 3 the middle estimate is 1.9-fold (0.27 log units) below the measured one, within the range that was stated.
By their numbers in this assay, from the lowest: compounds 2, 3 and 1 (each within the scatter of the next, the first and the last beyond it).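

In this assay, among the compounds shown here, placing 5-chloro-2-methylphenyl in place of 3-(trifluoromethyl)phenyl on the aromatic nitrogen gives a 2.0-fold higher number from compound 2 to compound 3 (0.29 log units; within the scatter) and is the first comparison here that differs at this position alone. The earlier pair differed in more than one place and could say nothing about this nitrogen, whereas this pair shows that these two carbon-only aromatic rings cannot be told apart in this measurement, even though the groups on them are quite different. Nothing measured here offers an explanation for the size of this step, and a single pair says nothing about how other groups at this position would behave.

The swap also removes the trifluoromethyl group and brings in chlorine and methyl together, so the part played by each of these groups cannot be separated. Also open, as far as these compounds go, is whether a quite different group on this nitrogen, such as a phenyl ring carrying a carboxylic acid, a pyridine ring or a plain butyl chain, would stay within the scatter of compound 2 in this assay or fall well outside it.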